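A few compounds are considered here, and "the series" means these few. Any claim that something is new, unique, unknown or untested is made for them only; others in the source may bear on it.

Compound 1, `CN1CCN(c2ccc(C3=NNC(c4ccc(N(C)C)cc4)C3)cc2)CC1`, gives 31.2% in a functional assay on HCC1806 cells (Homo sapiens) for inhibition, read by sulforhodamine B assay, tested at 10 uM; a higher number here means more inhibition at the concentration tested (going by the name of the read-out), a lower number less inhibition.
Compound 2, `CN1CCN(c2ccc(C3=NN(S(=O)(=O)C4CC4)C(c4ccc(N(C)C)cc4)C3)cc2)CC1`, gives 4.7% in this assay.

Among the compounds with values here, of the two numbers measured so far, compound 2 stands lowest; its nearest neighbour is compound 1, and the only measured step, a number 26.5 percentage points lower from compound 1 to compound 2 (beyond the scatter), tells how far apart they lie. That step concerns adding a cyclopropylsulfonyl group where a hydrogen had been.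

Compound 3, `CN1CCN(c2ccc(C3=NN(S(=O)(=O)c4ccc(F)cc4)C(c4ccc(N(C)C)cc4)C3)cc2)CC1`, keeps that sulfonyl group but changes what sits on it: 4-fluorophenyl in place of cyclopropyl on a sulfonyl sulfur. Within the data shown here, no measured step covers an exchange of one group for another on the sulfonyl sulfur, so the step from compound 1 to compound 2 bears on it only loosely, by showing that a sulfonyl substituent at this nitrogen lowered the read-out. Compound 3 is therefore expected to stay close to compound 2, with a step of a number 3.3 percentage points higher from compound 2 to compound 3 (within the scatter) that may well fall within the scatter. The estimate for compound 3 is 8%, within the range -5% to 22%.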

Compound 3, a percentage reported as inhibition, at one concentration (the size of the read-out at that concentration, not a potency): 92.3%
Estimate against measurement, compound 3: 84.3 percentage points below; measured number outside the range, above it.
By their numbers in this assay, from the lowest: compound 2; then compound 1; then compound 3.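

The sulfonyl link at this ring nitrogen does not fix the outcome in this assay on its own, since the group on the sulfonyl sulfur matters greatly: 4-fluorophenyl in place of cyclopropyl gives a number 87.6 percentage points higher from compound 2 to compound 3 (beyond the scatter) in this pair. Adding a sulfonyl group to the hydrogen-bearing nitrogen can therefore move the number either way, with cyclopropylsulfonyl giving a number 26.5 percentage points lower from compound 1 to compound 2 (beyond the scatter) and (4-fluorophenyl)sulfonyl giving a number 61.1 percentage points higher from compound 1 to compound 3 (beyond the scatter) for these compounds. No available evidence explains why these two groups differ so sharply.

From the compounds shown here alone, it remains open whether the gain follows the aromatic ring or its fluorine, a question that plain phenyl or 4-methoxyphenyl on the sulfonyl sulfur would address. A straight butyl chain there would also show whether a larger group without an aromatic ring behaves like cyclopropyl or like 4-fluorophenyl.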